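Cyclohexylamino to 4-Iodophenylamino: a Step Expected From Limits

A few compounds are considered here, and "the series" means these few. Any claim that something is new, unique, unknown or untested is made for them only; others in the source may bear on it.

Compound 1 `O=C1C=C(NC2CCCCC2)C(=O)c2c1nc1n2[C@H]2OC[C@@H](O)[C@H]2OC1` was tested in a functional assay on ECa-109 cells for inhibition, with ECa-109 cell line (Homo sapiens) as the target, read by sulforhodamine B assay; a lower number here means a stronger inhibitor, a higher number a weaker inhibitor. In this assay compound 1 reaches only the limit > 16000 nM, a boundary of the measurement rather than a number. Compound 2 `O=C1C(N2CCCCC2)=CC(=O)c2c1nc1n2[C@H]2OC[C@@H](O)[C@H]2OC1` likewise gives only the limit > 8000 nM. Compound 3 `O=C1C(NCc2ccccc2)=CC(=O)c2c1nc1n2[C@H]2OC[C@@H](O)[C@H]2OC1` also stops at the limit > 8000 nM. Going by the values given here, the single step between measured compounds, a step that the two limits leave unreadable from compound 2 to compound 3, cannot be read because both of its ends are limits (the limit of > 8000 nM in this assay, at which 2 of the 3 values shown sit). Compound 4 `O=C1C=C(Nc2ccc(I)cc2)C(=O)c2c1nc1n2[C@H]2OC[C@@H](O)[C@H]2OC1` differs from compound 1 by 4-iodophenyl in place of cyclohexyl on an amine nitrogen. Among the compounds with values here, no measured step changes the group on this amine nitrogen, so the three limits are the only guide. The step that the limit leaves unreadable from compound 1 to compound 4 is therefore expected to be small. Compound 4 is estimated at 20000 nM, ranging from 5000 nM to 80000 nM.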

Compound 4, half-maximal inhibitory concentration: 2300 nM
The estimate for compound 4 lay 8.7-fold (0.94 log units) above the measured number; the whole stated range lies above it.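

Going by these compounds alone, putting 4-iodophenyl in place of cyclohexyl on this amine nitrogen gives an at least 6.9-fold lower number from compound 1 to compound 4 (0.84 log units; beyond the scatter) in this assay, the first step that can be read. Compound 4 is also the only compound shown with a number rather than a limit, so the group on this nitrogen can move the read-out. How large the step really is stays open at one end, since compound 1 stops at a limit: the limit of > 16000 nM in this assay, at which 1 of the 4 values shown sits.

The compounds shown do not separate the effect of the aromatic ring from that of the iodine. A plain phenyl or a 4-chlorophenyl on the same nitrogen would tell the two apart.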